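From Compound 1 to Compound 3: One Ring Group Exchanged

The compounds below may be only part of what the source reports. "The series", "measured", "known", "first", "only" and "open" are said of these compounds alone.

Measured in an ADME assay on liver (Mus musculus) for metabolic stability, read by LC-MS, using microsomes and NADPH; on this read-out lower numbers stand for a less stable compound and higher numbers for a more stable compound:
Compound 1 `Cc1cc(CN(CC2CC2)C(CC(=O)O)c2ccc(Cl)cc2)ccc1OCCN1C(=O)CCC1=O`: 83%
Compound 2 `CCCCN(Cc1ccc(OCCN2C(=O)CCC2=O)c(C)c1)C(CC(=O)O)c1ccc(Cl)cc1`: 88%

Within the data shown here, only two compounds have been measured so far. Propyl in place of cyclopropyl on a saturated chain carbon bound to an amine nitrogen gives a number 5 percentage points higher from compound 1 to compound 2 (within the scatter). Among the measured compounds shown here, compound 1, at 83%, therefore stands level with its only neighbour once the scatter is allowed for.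

Compound 3 `Cc1cc(CN(CC2CC2)C(CC(=O)O)c2ccc(Cl)cc2)ccc1OCCn1c(=O)ccn(C)c1=O` keeps the rest of compound 1 but loses the 2,5-dioxopyrrolidin-1-yl group: a group of 9 heavy atoms (5 carbon, 2 nitrogen, 2 oxygen; one six-membered aromatic ring with 2 hetero atoms) in place of a group of 7 heavy atoms (4 carbon, 1 nitrogen, 2 oxygen; one five-membered non-aromatic ring with 1 hetero atom), on a saturated chain carbon, two bonds along the chain from an oxygen on an aromatic ring. For the measured compounds named here, no measured pair shows a change at this place, so the data offer no direct guide. Going by the values given here, the one available step, a number 5 percentage points higher from compound 1 to compound 2 (within the scatter), lies at a different place and gives only indirect support: one change to this molecule left the reading within the scatter. A step beyond the scatter in this assay is therefore not expected, although the new group makes the outcome uncertain in either direction. The expected step is a number 3 percentage points lower from compound 1 to compound 3 (within the scatter). The estimate for compound 3 is 80%, with an expected range from 65% to 93%.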

Compound 3, percent of the compound remaining: 24%
Compound 3: the middle estimate sits 56 percentage points above what was measured; the whole stated range lies above it.
By their numbers in this assay, from the lowest: compound 3; then compounds 1 and 2 (each within the scatter of the next).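

In this assay, among these compounds, the group on the saturated chain carbon, two bonds along the chain from an oxygen on an aromatic ring, proves able to shift the reading far more than the one earlier change did: exchanging 2,5-dioxopyrrolidin-1-yl for the six-membered aromatic ring with 2 hetero atoms gives a number 59 percentage points lower from compound 1 to compound 3 (beyond the scatter), whereas the change on the amine nitrogen gave a number 5 percentage points higher from compound 1 to compound 2 (within the scatter). The high readings of the first two compounds were therefore not secured by the shared core alone, since compound 3 keeps all the rest of compound 1 and still gives a far lower number. No measurement shown here accounts for this drop in the percent of compound remaining.

This single exchange alters ring size, aromatic character and atom count together, so the compounds shown cannot tell which of these matters, and a six-membered non-aromatic 2,6-dioxopiperidin-1-yl group would help to separate them. Going by these compounds, it also remains open whether a butyl chain on the amine nitrogen, as in compound 2, would leave the reading of the compound 3 type within the scatter.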